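Amide nitrogen substituent change in an E-selectin binder series

This account rests on a few compounds, and the source may have more. Where it says the series, first, only, none or still open, it means among the compounds named here.

Measured compounds:
compound 1 `CCCCCCCCCCOc1cc(OCCCCCCCCCC)cc(OCCCCCC(=O)N(c2ccc(C(=O)O)cc2)c2cccc(C(=O)O)c2)c1` — "not determined" (no result reported)
compound 2 `CCCCCCCCCCOc1cc(OCCCCCCCCCC)cc(OCCCCCC(=O)N(Cc2ccc(C(=O)O)cc2)c2cccc(C(=O)O)c2)c1` — 43%

In an assay on isolated protein for binding affinity to E-selectin (Homo sapiens), read by ELISA, tested at 100 uM (on this read-out higher numbers stand for more inhibition at the one concentration tested (going by the name of the read-out) and lower numbers for less inhibition), compound 2 gives 43%. Among the compounds with values here, this is the only number in hand for the series; compound 1 carries "not determined" (no result reported), so compound 2 stands alone and no step between measured compounds can be read.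

Compound 3 `CCCCCCCCCCOc1cc(OCCCCCCCCCC)cc(OCCCCCC(=O)N(c2cccc(C(=O)O)c2)c2ccc(C(=O)O)c(C(=O)O)c2)c1` differs from compound 2 in one place: 3,4-dicarboxyphenyl in place of 4-carboxybenzyl on an amide-type nitrogen. Within the data shown here, with no measured step in this assay to compare against, the size of this change cannot be anchored by the data; the expectation is a step of no more than the usual scatter in either direction, with a slight lean toward more inhibition on this read-out for compound 3.

Compound 3 is therefore expected to give about 48% in this assay, in the range 22% to 72%, which means an expected step of a number 5 percentage points higher from compound 2 to compound 3 (within the scatter).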

Compound 3, a percentage reported as inhibition, at one concentration (the size of the read-out at that concentration, not a potency): 62%
Compound 3: middle estimate off by 14 percentage points, on the low side; low and high end bracket the measured number.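

Within the data shown here, on the amide-type nitrogen, 3,4-dicarboxyphenyl in place of 4-carboxybenzyl gives the first readable change in this assay: a number 19 percentage points higher from compound 2 to compound 3 (beyond the scatter), so inhibition at this position does respond to the substituent. The exchange alters two things at once, the benzyl becoming a phenyl and the number of carboxylic acids rising, and this single step cannot assign the gain to either. Nothing in hand accounts for the step.

Steps to compound 1, which stands at "not determined" (no result reported), cannot be read, so the 4-carboxyphenyl group offers no way to separate the two changes. Open questions are whether a dicarboxybenzyl group on the same nitrogen would keep the gain and whether a tetrazole could stand in for either carboxylic acid.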